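The source may report more compounds than this note shows. Statements on the series, on what has been measured and on what is new or still open speak of the compounds shown alone.

Compound 1 `Cc1ccc2c(c1)/C(=N/NC(=S)NO)C(=O)N2CN1CCN(c2ccccc2)CC1` gives 420000 nM in an ADME assay on MT4 cells (Homo sapiens) for cytotoxicity, read by spectrophotometry, with a stated time of 5 days; a lower number here means that less compound is tolerated, a higher number that more compound is tolerated.
Compound 2 `COc1ccc(N2CCN(CN3C(=O)/C(=N\NC(=S)NO)c4cc(C)ccc43)CC2)cc1` gives 321000 nM in this assay.
Compound 3 `CONC(=S)N/N=C1\C(=O)N(CN2CCN(c3ccccc3)CC2)c2ccc(Cl)cc21` gives 267000 nM in this assay.

Compound 2 differs from compound 1 by methoxy in place of hydrogen on an aromatic carbon, and this change made a 1.3-fold lower number from compound 1 to compound 2 (0.12 log units; within the scatter). Compound 3 carries a different core; how it differs from compound 1 is not broken down here, and its value in this assay sits close to those of compound 1 and compound 2, all three within the usual scatter of one another. Compound 4 `CONC(=S)N/N=C1\C(=O)N(CN2CCN(c3ccc(OC)cc3)CC2)c2ccc(Cl)cc21` is not yet measured. It differs from compound 3 by methoxy in place of hydrogen on an aromatic carbon, the same change, at the same kind of place, as from compound 1 to compound 2. Because that earlier step was a 1.3-fold lower number from compound 1 to compound 2 (0.12 log units; within the scatter), compound 4 is expected to stay near compound 3, with an estimated step of a 1.2-fold lower number from compound 3 to compound 4 (0.06 log units; within the scatter). The estimate for compound 4 in this assay is 230000 nM, between 120000 nM and 450000 nM.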

Compound 4, half-maximal cytotoxic concentration: 221000 nM
Beside the measured number, compound 4's estimate is 1.0-fold (0.02 log units) above it; the range from low to high includes it.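

In this assay, going from phenyl to 4-methoxyphenyl gives a 1.2-fold lower number from compound 3 to compound 4 (0.08 log units; within the scatter), so on this second core the change again leaves the number within the usual scatter. Set side by side, the two steps agree: the same change on two cores in this assay, a 1.3-fold lower number (0.12 log units; within the scatter) from compound 1 to compound 2 and a 1.2-fold lower number (0.08 log units; within the scatter) from compound 3 to compound 4, 1.1-fold (0.03 log units) apart, within the scatter of two such steps. This shows that the change carried over between these two cores with no step beyond the scatter, but two small steps cannot show that it would behave the same way on any other core or in any other assay.

From the compounds shown here alone, it remains open whether a different group at that place on the phenyl ring, such as an amine, a carboxylic acid or a longer chain, would move the number beyond the scatter.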